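The source may hold more compounds than are shown below. What is called first, only, known or untested is meant among the compounds shown, and "the series" means these compounds.

Measured so far:
compound 1 `Oc1cccc2[nH]c(-c3ccc(-c4ccc(-c5ccccc5)cc4)cc3)nc12` — 2200 nM
compound 2 `Oc1cccc2[nH]c(-c3ccc(-c4ccc(-c5ccc(F)cc5)cc4)cc3)nc12` — 3010 nM
compound 3 `Cc1ccc2[nH]c(-c3ccc(-c4ccc(-c5ccccc5)cc4)cc3)nc2c1` — 31600 nM

In a functional assay on MCF7 cells (Homo sapiens) for inhibition, read by sulforhodamine B assay (a lower number here means a stronger inhibitor of growth, a higher number a weaker inhibitor of growth), compound 1 gives 2200 nM and compound 2 gives 3010 nM. The change between them is fluoro in place of hydrogen on an aromatic carbon, and it made a 1.4-fold higher number from compound 1 to compound 2 (0.14 log units; within the scatter). In this assay compound 3 gives 31600 nM, a higher number than compound 1 or compound 2 show; the difference between the core of compound 3 and the core of compound 1 is not broken down here.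

Compound 4 `Cc1ccc2[nH]c(-c3ccc(-c4ccc(-c5ccc(F)cc5)cc4)cc3)nc2c1` is not yet measured. It differs from compound 3 by fluoro in place of hydrogen on an aromatic carbon, the same change as from compound 1 to compound 2, at the same place, read one bond further out as phenyl to 4-fluorophenyl. For compound 4 a step of a 1.3-fold higher number from compound 3 to compound 4 (0.10 log units; within the scatter) in this assay is expected, resting on what the same change gave in a 1.4-fold higher number from compound 1 to compound 2 (0.14 log units; within the scatter). Compound 4 is therefore estimated at 40000 nM in this assay. The expected range for compound 4 runs from 18000 nM to 90000 nM.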

Compound 4, concentration for 50% growth inhibition: 30200 nM
Compound 4: the middle estimate sits 1.3-fold (0.12 log units) above what was measured; the range from low to high includes it.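

In this assay, fluoro in place of hydrogen on an aromatic carbon gives a 1.0-fold lower number from compound 3 to compound 4 (0.02 log units; within the scatter), so on this core too the change leaves the read-out within the scatter. Set side by side, the steps on the two cores agree: the same change on two cores in this assay, a 1.4-fold higher number (0.14 log units; within the scatter) from compound 1 to compound 2 and a 1.0-fold lower number (0.02 log units; within the scatter) from compound 3 to compound 4, 1.4-fold (0.16 log units) apart, within the scatter of two such steps. This shows the change carrying over between these two cores as a step too small to read, but it rests on a single pair of cores and a single place, and two steps within the scatter do not show that a larger step would carry over in the same way.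

Open, on these data alone, is whether an amine, a carboxylic acid or a methoxy group at this place gives a step beyond the scatter on either core. If one does, it remains to be seen whether the two cores still agree.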